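A few compounds are considered here, and "the series" means these few. Any claim that something is new, unique, unknown or untested is made for them only; others in the source may bear on it.

Measured compounds:
- compound 1, `CN(C)C(=O)c1cc2cnc(Nc3ccc(NC(=O)C4(C(=O)Nc5ccc(F)cc5)CC4)cc3F)nc2n1C1CCCC1` — -0.9%
- compound 2, `CN(C)C(=O)c1cc2cnc(Nc3ccc(NC(=O)C4(C(=O)Nc5ccc(Br)cc5)CC4)cc3)nc2n1C1CCCC1` — 13.7%

Both compounds share one core and were tested in a functional assay on OVCAR-5 cells (Homo sapiens) for inhibition, read by CCK-8 assay, with a stated time of 72 h, tested at 1 uM; a higher number here means more inhibition of growth at the concentration tested, a lower number less inhibition of growth. Compound 1 gives -0.9%, which amounts to no measurable inhibition of growth at the tested concentration. Compound 2 gives 13.7%, the higher of the two numbers, and its distance from compound 1 lies beyond the usual scatter. The two compounds differ in more than one place, so only their two values can be compared, not a single change.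

Compound 3, `CN(C)C(=O)c1cc2cnc(Nc3ccc(NC(=O)C4(C(=O)Nc5ccc(O)cc5)CC4)cc3)nc2n1C1CCCC1`, has not yet been measured. It comes from compound 2 by one change: hydroxy in place of bromo on an aromatic carbon. With only two measured points, both weak, there is no basis for expecting a large move in either direction, and the step from compound 2 to compound 3 is estimated to be small, a number 5.7 percentage points lower from compound 2 to compound 3 (within the scatter), within the scatter. Compound 3 is therefore expected to give about 8% in this assay, plausibly anywhere between -8% and 25%.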

Compound 3, percent growth inhibition at one concentration: 80.7%
Estimate against measurement, compound 3: 72.7 percentage points below; the whole stated range lies below it.
By their numbers in this assay, from the lowest: compound 1; then compound 2; then compound 3.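

In this assay, replacing bromo with hydroxy on the aromatic carbon gives a number 67 percentage points higher from compound 2 to compound 3 (beyond the scatter), so exchanging one heavy atom for another at this place can separate weak from strong inhibition of growth. The earlier compounds shown here could not show this, since compound 1 and compound 2 differ in more than one place and neither value could be tied to this position. Nothing available here explains why the hydroxy compound stands so far above the bromo compound.

The compounds shown leave open whether the gain belongs to hydroxy alone or would also appear with an amine, a methoxy group or a carboxylic acid at the same place. They also leave open whether hydroxy would have the same effect on compound 1.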